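The source may report more compounds than this note shows. Statements on the series, on what has been measured and on what is new or still open speak of the compounds shown alone.

Measured so far in a functional assay on MCF7 cells (Homo sapiens) for antiproliferative activity, read by MTT assay, with a stated time of 72 h; on this read-out higher numbers stand for weaker inhibition and lower numbers for stronger inhibition:
- compound 1 `C=CC/N=C1\S/C(=C\c2ccc(OC)cc2)C(=O)N1C`: > 100000 nM
- compound 2 `COc1ccc(/C=C2/CN(C)/C(=N/c3ccc(C(C)(C)C)cc3)S2)cc1`: 28700 nM
- compound 3 `C=C1CN(C)/C(=N/c2ccccc2)S1`: > 100000 nM

Compound 1 gives > 100000 nM, which is a limit and not a number. It stands at the limit of > 100000 nM in this assay, at which 2 of the 3 values shown sit. Compound 3 gives > 100000 nM, which is also a limit. Among the measured compounds shown here, compound 2 gives 28700 nM, the only actual number.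

Compound 4 `COc1ccc(/C=C2\S/C(=N\c3ccc(C)c(Cl)c3)N(C)C2=O)cc1` has 3-chloro-4-methylphenyl in place of allyl on a double-bonded nitrogen of compound 1: 3-chloro-4-methylphenyl in place of allyl on a double-bonded nitrogen. For the measured compounds named here, no step between measured compounds is available to size this change. Going by the values given here, with compound 2 at 28700 nM as the only numerical guide, a moderate shift towards stronger inhibition is expected in this assay. A result at the limit remains quite possible. Compound 3 goes against any general gain from an aromatic group on that nitrogen. The expected change is an at least 2.5-fold lower number from compound 1 to compound 4 (0.39 log units; beyond the scatter). The estimate for compound 4 is 40000 nM, with an expected range of 10000 nM to 100000 nM.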

Compound 4, half-maximal inhibitory concentration: > 100000 nM
Compound 4 ended at the assay's limit; the forecaster's own chance of this, stated with the estimate: 40%; middle value at least 2.5-fold (0.39 log units) from the limit.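

Compound 1 and compound 4 both sit at a limit in this assay, and the step between them cannot be read: the limit of > 100000 nM in this assay, at which 3 of the 4 values shown sit.

The compounds shown leave open whether 3-chloro-4-methylphenyl in place of allyl on a double-bonded nitrogen changes inhibition at all; only compound 2 carries an actual number.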